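Methyl in place of isopropyl: notes on compound 3

This account rests on a few compounds, and the source may have more. Where it says the series, first, only, none or still open, it means among the compounds named here.

compound 1 `CC(C)(C)c1cc(OC(=O)c2ccccc2)ccc1O`: < 0.25 h (a limit)
compound 2 `CC(C)c1cc(NC(=O)c2ccc(Cl)cc2Cl)ccc1O`: > 1 h (a limit)

Both entries come from an ADME assay on a cell-free system (serum) for metabolic stability (a lower number here means that the compound disappears faster, a higher number that the compound lasts longer), and neither is a number. In this assay compound 2 gives > 1 h, which is a limit of the assay. Compound 1 gives < 0.25 h, also a limit. Within the data shown here, the two compounds thus sit on opposite sides of the range that has been read so far, and no measured pair differs in one place only.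

Compound 3 `Cc1cc(NC(=O)c2ccc(Cl)cc2Cl)ccc1O` has not yet been measured. Compared with compound 2, it carries methyl in place of isopropyl on an aromatic carbon, ortho to a hydroxy group and meta to a large group: methyl in place of isopropyl on an aromatic carbon.

Among the measured compounds shown here, with no measured step to draw on, the expectation rests on compound 2 and its limit of > 1 h. No step beyond the scatter is expected in this assay, in either direction. The expected change is a step that the limit leaves unreadable from compound 2 to compound 3. Compound 3 is estimated at 1.5 h, with an expected range of 0.6 h to 5 h. A report as a limit alone is also quite likely.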

Compound 3, half-life: > 1 h
Compound 3: only a limit was reported; the forecaster's own chance of this, stated with the estimate: 60%; the middle value lies beyond the limit too.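

Compound 2 and compound 3 both stand at a limit in this assay, so no step can be read between them for methyl in place of isopropyl. The compounds shown leave open how long either compound actually lasts, and whether this change on an aromatic carbon alters the half-life at all.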